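A naphthalene arm on the methylpiperazine-bearing core

A few compounds are considered here, and "the series" means these few. Any claim that something is new, unique, unknown or untested is made for them only; others in the source may bear on it.

Two compounds have been measured in a functional assay on RPMI 8402 cells (Homo sapiens) for cytotoxicity; on this read-out higher numbers stand for weaker inhibition and lower numbers for stronger inhibition:
compound 1, `NC(=O)c1ccc2[nH]c(-c3ccc4[nH]c(-c5cccc6ccccc56)nc4c3)nc2c1`, gives 3700 nM;
compound 2, `Cc1ccc(-c2nc3cc(-c4nc5cc(N6CCN(C)CC6)ccc5[nH]4)ccc3[nH]2)cc1`, gives 830 nM.

Compound 2 holds the lower of the two numbers, and compound 1 sits beyond the scatter above it. Compound 3, `CN1CCN(c2ccc3[nH]c(-c4ccc5[nH]c(-c6cccc7ccccc67)nc5c4)nc3c2)CC1`, changes one end of compound 2: naphthalen-1-yl in place of 4-methylphenyl on an aromatic carbon. Among the compounds with values here, no measured pair isolates this change. Since compound 1 carries the same naphthalen-1-yl on a different partner and gives 3700 nM, a modest weakening, or none beyond the scatter, is expected. Compound 3 is estimated at 1100 nM, plausibly between 350 nM and 3500 nM. The expected step is a 1.3-fold higher number from compound 2 to compound 3 (0.12 log units; within the scatter) in this assay.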

Compound 3, half-maximal inhibitory concentration: 330 nM
Estimate against measurement, compound 3: 3.3-fold (0.52 log units) above, outside the stated range (below it).
By their numbers in this assay, from the lowest: compound 3; then compound 2; then compound 1.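

In this assay naphthalen-1-yl in place of 4-methylphenyl on an aromatic carbon between two ring nitrogen atoms gives a 2.5-fold lower number from compound 2 to compound 3 (0.40 log units; beyond the scatter) and so shows that the second aromatic ring of naphthalen-1-yl is accepted at this position. With naphthalen-1-yl on both compounds, 4-methylpiperazin-1-yl in place of carbamoyl gives an 11-fold lower number from compound 1 to compound 3 (1.05 log units; beyond the scatter) and so shows that the high number of compound 1 does not carry over to this partner. Nothing at hand explains either step. From the compounds shown here alone, whether a pyridine ring or a methoxy group on the phenyl ring would move the number further remains open.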